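Dropping the Chloro Group: Expected Effect on Maximal Response

The compounds below may be only part of what the source reports. "The series", "measured", "known", "first", "only" and "open" are said of these compounds alone.

Compound 1 `CCCn1ccc2cc(-c3cccnc3)cc(Cl)c2c1=O`: 83%
Compound 2 `CCCn1ccc2cc(-c3cncnc3)cc(Cl)c2c1=O`: 28%

In a functional assay on CHO cells for agonist activity at metabotropic glutamate receptor 2 (Homo sapiens), read by GTPgammaS binding (on this read-out lower numbers stand for smaller maximal responses and higher numbers for larger maximal responses), compound 1 reaches 83%, the highest of the two numbers measured. Going by the values given here, compound 2 reaches 28%, and the only measured step, a number 55 percentage points lower from compound 1 to compound 2 (beyond the scatter), comes from pyrimidin-5-yl in place of pyridin-3-yl on an aromatic carbon. Compound 3 `CCCn1ccc2cc(-c3cccnc3)ccc2c1=O` differs from compound 1 by hydrogen in place of chloro on an aromatic carbon. Among the compounds with values here, no measured step touches the chloro group, so the single known step offers no direct guide to this change. Compound 3 is therefore expected to stay close to compound 1, with a number 8 percentage points lower from compound 1 to compound 3 (within the scatter) not beyond the scatter. The estimate for compound 3 is 75%, within a range of 50% to 95%.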

Compound 3, largest response reached (Emax), in percent of the reference or control that the assay uses: 81%
For compound 3 the middle estimate is 6 percentage points below the measured one, within the range that was stated.
By their numbers in this assay, from the lowest: compound 2; then compounds 3 and 1 (each within the scatter of the next).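

Hydrogen in place of chloro on this aromatic carbon gives (a number 2 percentage points lower from compound 1 to compound 3 (within the scatter)) in this assay. The chlorine atom is therefore not required for the large maximal response of compound 1, a point the earlier step at the pyridin-3-yl group could not show. Nothing available explains the result at this position.

Going by these compounds, whether fluoro, methoxy or an amine on this carbon would keep the response remains open. So does whether pyrimidin-5-yl in place of pyridin-3-yl would cost as much in the absence of chloro.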